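A few compounds are considered here, and "the series" means these few. Any claim that something is new, unique, unknown or untested is made for them only; others in the source may bear on it.

Three compounds were measured in a functional assay on EL4 cells (Mus musculus) for inhibition, tested at 100 uM; a higher number here means more inhibition at the concentration tested (going by the name of the read-out), a lower number less inhibition. Compound 1 `CN(C)c1nccc2c1ncn2C1O[C@H](CO)[C@@H](O)[C@H]1O` shows 10% in this assay. For compound 2 `[O-][n+]1ccc2c(c1)ncn2C1O[C@H](CO)[C@@H](O)[C@H]1O` this assay reports only a limit, < 5%. For compound 3 `[N-]=[N+]=Nc1[nH]ccc2ncnc1-2` this assay likewise reports only a limit, < 5%, so compound 3 stands at the lower edge of what this assay can resolve, a position it shares with one other value here, as the limit of < 5% in this assay, at which 2 of the 3 values shown sit, shows. Compound 4 `Sc1[nH]ccc2ncnc1-2` is not yet measured; it differs from compound 3 by sulfanyl in place of azido on an aromatic carbon. Since compound 3 sits at a limit, the expected change from compound 3 to compound 4 is a number at least 3 percentage points higher from compound 3 to compound 4 (that floor lies within the scatter), no more than the usual scatter. Compound 4 is therefore expected to give about 8%, somewhere between 0% and 25%.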

Compound 4, a percentage reported as inhibition, at one concentration (the size of the read-out at that concentration, not a potency): < 5%
Compound 4 gave a limit, no number (the forecaster's own chance of this, stated with the estimate: 50%); middle value at least 3 percentage points from the limit.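

Compound 3 and compound 4 both give only a limit, not a number, so no step between them can be read: the limit of < 5% in this assay, at which 3 of the 4 values shown sit.

As far as these compounds go, whether sulfanyl in place of azido on this aromatic carbon changes inhibition at all remains open.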